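Replacing Nitro with Hydrogen in Compound 1

The source may hold more compounds than are shown below. What is called first, only, known or untested is meant among the compounds shown, and "the series" means these compounds.

- compound 1 `O=C(CSc1nncnc1-c1cccc2ccccc12)Nc1ccccc1[N+](=O)[O-]`: 142000 nM
- compound 2 `O=C(CSc1nncnc1-c1ccccc1Cl)Nc1ccccc1`: 127000 nM

In an ADME assay on MT4 cells (Homo sapiens) for cytotoxicity, read by MTT assay (a higher number here means that more compound is tolerated, a lower number that less compound is tolerated), compound 1 gives 142000 nM and compound 2 gives 127000 nM, two numbers within the usual scatter of each other. Compound 3 `O=C(CSc1nncnc1-c1cccc2ccccc12)Nc1ccccc1` has hydrogen in place of nitro on an aromatic carbon, so 2-nitrophenyl becomes phenyl: hydrogen in place of nitro on an aromatic carbon. Within the data shown here, no measured pair shows this change. Like compound 3, compound 2 is an anilino compound and stands at 127000 nM, so no step beyond the scatter is expected in this assay. The expected step is a 1.1-fold lower number from compound 1 to compound 3 (0.06 log units; within the scatter). The estimated value for compound 3 is 125000 nM, with an expected range of 60000 nM to 260000 nM.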

Compound 3, half-maximal cytotoxic concentration: 154000 nM
Compound 3: the middle estimate sits 1.2-fold (0.09 log units) below what was measured; the range from low to high includes it.
By their numbers in this assay, from the lowest: compounds 2, 1 and 3 (each within the scatter of the next).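

In this assay, among these compounds, hydrogen in place of nitro on this aromatic carbon gives a 1.1-fold higher number from compound 1 to compound 3 (0.04 log units; within the scatter) and so provides the first direct reading of this change, whereas compound 1 and compound 2 differ in more than one place. At this place, ortho to a large group, the nitro group can thus leave without a step beyond the scatter. No evidence on the reason for this result is at hand. Going by these compounds, whether an amine or a carboxylic acid at this place would also stay within the scatter remains open.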